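The source may report more compounds than this note shows. Statements on the series, on what has been measured and on what is new or still open speak of the compounds shown alone.

In an ADME assay on a cell-free system (plasma, Homo sapiens) for protein binding (on this read-out lower numbers stand for a smaller free fraction and higher numbers for a larger free fraction), compound 1 `Cn1cnc(S(=O)(=O)N2C[C@@H]3[C@H](C2)[C@@]3(CNC(=O)c2c(Cl)cccc2Cl)CC2CC2)c1` gives 0.08, compound 2 `Cn1cnc(S(=O)(=O)N2C[C@@H]3[C@H](C2)[C@@]3(CNC(=O)c2cccc(C(F)(F)F)c2)CC2CC2)c1` gives 0.04 and compound 3 `Cn1cnc(S(=O)(=O)N2C[C@@H]3[C@H](C2)[C@@]3(CNC(=O)c2ccc(Cl)cc2)CC2CC2)c1` gives 0.03. Compound 3 sits at the low end, level with compound 2. The measured gaps are a 1.3-fold lower number from compound 2 to compound 3 (0.12 log units; within the scatter) and a 2.7-fold lower number from compound 1 to compound 3 (0.43 log units; beyond the scatter). Compound 4 `Cn1cnc(S(=O)(=O)N2C[C@@H]3[C@H](C2)[C@@]3(CNC(=O)c2ccc(Cl)cc2Cl)CC2CC2)c1` differs from compound 3 by one change, (chloro in place of hydrogen on an aromatic carbon), which gives a 2,4-dichlorophenyl. Among the compounds with values here, no measured step makes this change alone. The nearest guide is a 2.7-fold lower number from compound 1 to compound 3 (0.43 log units; beyond the scatter), but that step compares 2,6-dichlorophenyl with 4-chlorophenyl, so it is only a weak hint. In this assay, the expected result is no change at the digits printed from compound 3 to compound 4 (within the scatter), with no shift beyond the scatter. The estimate for compound 4 is 0.03, with an expected range from 0.015 to 0.06.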

Compound 4, unbound fraction: 0.05
The estimate for compound 4 lay 1.7-fold (0.22 log units) below the measured number; measured number inside the range.
By their numbers in this assay, from the lowest: compounds 3, 2, 4 and 1 (each within the scatter of the next, the first and the last beyond it).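

In this assay, within the data shown here, the added chloro, ortho to a large group, gives a 1.7-fold higher number from compound 3 to compound 4 (0.22 log units; within the scatter) and so gives the first direct reading of this single change, which stays inside the usual scatter. The 2,4-dichlorophenyl also shows a 1.3-fold higher number from compound 2 to compound 4 (0.10 log units; within the scatter) and a 1.6-fold lower number from compound 1 to compound 4 (0.20 log units; within the scatter) so compound 4 lies within the scatter of compound 1, compound 2 and compound 3, even though compound 1 and compound 3 stand apart. Nothing available explains these numbers. On these data alone, whether a methoxy or an amine on this same aromatic carbon would behave like chloro remains open.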